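Urea to Amide: Estimating Compound 4 Against Prostate Cancer Cells

This account rests on a few compounds, and the source may have more. Where it says the series, first, only, none or still open, it means among the compounds named here.

Measured so far:
- compound 1 `COc1cc(-c2nn(-c3cccc(NC(=O)Nc4cc(C(F)(F)F)cc(C(F)(F)F)c4)c3)cc2-c2ccncc2)ccc1Cl`: 1310 nM
- compound 2 `COc1cc(-c2nn(-c3cccc(NC(=O)Nc4ccc(Cl)c(Cl)c4)c3)cc2-c2ccncc2)ccc1Cl`: 1520 nM
- compound 3 `O=C(Nc1cccc(-n2cc(-c3ccncc3)c(-c3ccc(Cl)c(O)c3)n2)c1)Nc1ccc(Cl)c(Cl)c1`: 1500 nM

These three compounds were tested in a functional assay on DU-145 cells (Homo sapiens) for inhibition, read by sulforhodamine B assay, with a stated time of 48 h; a higher number here means a weaker inhibitor of growth, a lower number a stronger inhibitor of growth. Compound 2 gives the highest of the three numbers, but its distance to the others is small: the step of a 1.0-fold lower number from compound 2 to compound 3 (0.01 log units; within the scatter) is within the scatter, and compound 1 differs from compound 2 by an amount that is also within the scatter. In practice all three behave alike in this assay.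

Compound 4 `COc1cc(-c2nn(-c3cccc(NC(=O)c4ccc(Cl)c(C(F)(F)F)c4)c3)cc2-c2ccncc2)ccc1Cl` is the next compound. It differs from compound 2 by one change: 4-chloro-3-(trifluoromethyl)phenyl in place of (3,4-dichlorophenyl)amino on a carbonyl carbon. The urea link of compound 2 therefore becomes an amide link in compound 4, and the aryl group at the end of that link changes as well.

Going by the values given here, none of the measured steps bears on this change. Among the compounds with values here, the only measured step, from compound 2 to compound 3, concerns the methyl on the oxygen and was within the scatter, and the two values of compound 1 and compound 2 show that swapping one substituted aryl ring for another at the end of the urea also left the number within the scatter. Within the data shown here, there is no measured example of replacing the urea itself.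

On that thin basis compound 4 is expected to land near the other three, with a 1.1-fold higher number from compound 2 to compound 4 (0.05 log units; within the scatter) as the estimated step, so the estimate is 1700 nM within a range of 500 nM to 6000 nM.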

Compound 4, concentration for 50% growth inhibition: 6390 nM
Estimate against measurement, compound 4: 3.8-fold (0.58 log units) below; the measured number lies above the stated range.
By their numbers in this assay, from the lowest: compounds 1, 3 and 2 (each within the scatter of the next); then compound 4.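

In this assay, the step of a 4.2-fold higher number from compound 2 to compound 4 (0.62 log units; beyond the scatter) is the only one shown that lies beyond the scatter, so the group on this carbonyl carbon is a place where the number can move, if modestly, towards weaker growth inhibition. The change is a double one: (3,4-dichlorophenyl)amino, which counts one hydrogen-bond donor, gives way to 4-chloro-3-(trifluoromethyl)phenyl, which counts none, so the urea link and the aryl ring change together and this single step cannot show which of the two carries the shift. No measurement at hand accounts for the shift.

Two groups on the same carbonyl carbon would pull these two parts apart: (4-chloro-3-(trifluoromethyl)phenyl)amino would keep the urea link with the new ring, while 3,4-dichlorophenyl would give the amide link with the old ring. The compounds shown also leave open whether the shift would persist with a hydroxyl in place of the methoxy group, as in compound 3, and how an unsubstituted phenyl ring would behave at this carbonyl carbon.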